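The source may report more compounds than this note shows. Statements on the series, on what has been measured and on what is new or still open speak of the compounds shown alone.

Oral exposure, measured in an ADME assay on the whole organism (Mus musculus, strain CD1) for pharmacokinetics, at a dose of 10 mg/kg by the oral route; a higher number here means more compound in the circulation at the dose given, a lower number less compound in the circulation:

Compound 1 `N#Cc1ncc(N2C(=O)C3(CCC3)N(c3ccc(CN4CCNCC4)cc3)C2=S)cc1C(F)(F)F` gives 8700 ng.h/mL.
Compound 2 `CN1CCC(Oc2ccc(N3C(=S)N(c4cnc(C#N)c(C(F)(F)F)c4)C(=O)C34CCC4)cn2)CC1` gives 10900 ng.h/mL.
Compound 3 `N#Cc1ncc(N2C(=O)C3(CCC3)N(c3ccc(OC4CCNCC4)nc3)C2=S)cc1Cl` gives 6000 ng.h/mL.

Among these three numbers compound 1 stands second highest; the gap to compound 2 and the gap to compound 3 both lie within the usual scatter of repeated measurements, so no ordering among the three is established and none of them can be called the best exposed.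

Compound 4 `CN1CCC(Oc2ccc(N3C(=S)N(c4cnc(C#N)c(C(F)(F)F)c4)C(=O)C34CCC4)cc2)CC1` is not yet measured. It is derived from compound 1 by one change: (1-methylpiperidin-4-yl)oxy in place of (piperazin-1-yl)methyl on an aromatic carbon. Compound 4 thereby carries the same side chain as compound 2, set on a six-membered aromatic ring of carbon only rather than the ring present in compound 2, and it keeps the trifluoromethyl and nitrile substituents that compounds 1 and 2 share. Going by the values given here, no measured pair isolates this change, so its effect cannot be read from the data; the expectation is a step of a 1.1-fold higher number from compound 1 to compound 4 (0.04 log units; within the scatter) from compound 1 to compound 4 that stays within the scatter, in no clear direction. Compound 4 is therefore estimated at 9500 ng.h/mL in this assay, with a range of 4500 ng.h/mL to 20000 ng.h/mL.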

Compound 4, area under the concentration-time curve: 9400 ng.h/mL
Estimate against measurement, compound 4: 1.0-fold (0.00 log units) above, and the stated range covers the measured number.
By their numbers in this assay, from the lowest: compounds 3, 1, 4 and 2 (each within the scatter of the next).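

In this assay, (1-methylpiperidin-4-yl)oxy in place of (piperazin-1-yl)methyl on the six-membered aromatic ring of carbon only, para to a large group, gives a 1.1-fold higher number from compound 1 to compound 4 (0.03 log units; within the scatter). Going by these compounds alone, at this position, therefore, a side chain without a hydrogen-bond donor and one with a hydrogen-bond donor cannot be told apart by this read-out, the first direct comparison. No measurement available here bears on why the step is this small.

The change alters the linking atom and the amine ring together, so the contribution of each remains unresolved. Also open, as far as these compounds go, is whether a carboxylic acid, or a longer chain between the aromatic ring and the amine, would stay within the scatter of compound 1 at this position.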